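A few compounds are considered here, and "the series" means these few. Any claim that something is new, unique, unknown or untested is made for them only; others in the source may bear on it.

Measured compounds:
- compound 1, `CC(C)(CC(=O)Nc1ccc(F)c(C(F)(F)F)c1)C(=O)O`, in a physicochemical assay for solubility, read by nephelometry, measured as kinetic solubility, at pH 2, tested at 10 mg/mL (a lower number here means a less soluble compound, a higher number a more soluble compound), compound 1 gives 25 ug/mL
- compound 2, `O=C(O)CNC(=O)Nc1ccc(F)c(C(F)(F)F)c1`, in this assay compound 2 gives > 100 ug/mL, a limit of the assay rather than a number
- compound 3, `O=C(Nc1ccc(F)c(C(F)(F)F)c1)NC1(C(=O)O)CCC1`, in this assay compound 3 gives 50 ug/mL

Compound 3 and compound 1 sit within the scatter of each other, so no order can be read between them. The value of compound 2 is a limit, as shown by the limit of > 100 ug/mL in this assay, at which 1 of the 3 values shown sits, and gives no exact number to compare. Compound 4, `CC(C)(NC(=O)Nc1ccc(F)c(C(F)(F)F)c1)C(N)=O`, has not been measured. It differs from compound 3 in one place: 1-carbamoyl-1-methylethyl in place of 1-carboxycyclobutyl on an amide-type nitrogen.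

Going by the values given here, two measured steps touch the same part of the molecule. The step of an at least 4.0-fold higher number from compound 1 to compound 2 (0.60 log units; beyond the scatter) and the step of an at least 2.0-fold lower number from compound 2 to compound 3 (0.30 log units; that floor lies within the scatter) both change the group on the amide-type nitrogen, yet both keep a carboxylic acid, whereas compound 4 carries a primary amide instead. Neither step therefore covers the change from compound 3 to compound 4 directly, and the one that comes closest, the step from compound 2 to compound 3, has a floor within the scatter. In this assay no step beyond the scatter is expected for compound 4, and the estimate is 40 ug/mL, between 15 ug/mL and 100 ug/mL, which as a step means a 1.3-fold lower number from compound 3 to compound 4 (0.10 log units; within the scatter).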

Compound 4, solubility: 50 ug/mL
The estimate for compound 4 lay 1.3-fold (0.10 log units) below the measured number; low and high end bracket the measured number.
By their numbers in this assay, from the lowest: compounds 1, 3 and 4 (each within the scatter of the next). At a limit, above all of these: compound 2.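

In this assay, going by these compounds alone, putting 1-carbamoyl-1-methylethyl in place of 1-carboxycyclobutyl on the amide-type nitrogen gives no change at the digits printed from compound 3 to compound 4 (within the scatter), so this position can carry a primary amide instead of the carboxylic acid found in all the earlier compounds, with no change beyond the scatter. The wider comparison, which also alters the link to the carbonyl carbon, agrees: a 2.0-fold higher number from compound 1 to compound 4 (0.30 log units; within the scatter). Compound 2 stands at a limit of the assay, so the step of an at least 2.0-fold lower number from compound 2 to compound 4 (0.30 log units; that floor lies within the scatter) sets only a floor and gives no exact gap: the limit of > 100 ug/mL in this assay, at which 1 of the 4 values shown sits.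

The step from compound 3 to compound 4 removes the cyclobutyl ring and the carboxylic acid together, so the compounds shown do not separate these two changes. On these data alone, how an amine or a hydroxyl group would read at this position also remains open.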